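Replacing 2-methoxyphenyl with 3-chloropropyl on compound 2

A few compounds are considered here, and "the series" means these few. Any claim that something is new, unique, unknown or untested is made for them only; others in the source may bear on it.

Of the compounds shown here, three have been tested in an ADME assay on HFF cells (Homo sapiens) for cytotoxicity, read by MTT assay, with a stated time of 72 h; on this read-out higher numbers stand for weaker inhibition and lower numbers for stronger inhibition. Among the compounds with values here, compound 2 `COc1ccccc1-c1cn(C[C@H](O)[C@H]2OC(=O)C(OCc3ccccc3)=C2OCc2ccccc2)nn1` gives 50 nM, the only exact number among them. Compound 1 `Cc1ccc(-c2cn(C/C=C3\OC(=O)C(OCc4ccccc4)=C3OCc3ccccc3)nn2)cc1` gives > 100000 nM, which is a limit of the assay and not a number. Compound 3 `O=C1O/C(=C\Cn2cc(-c3cc(C(F)(F)F)cc(C(F)(F)F)c3)nn2)C(OCc2ccccc2)=C1OCc1ccccc1` gives > 100000 nM, which is also a limit and not a number.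

Compound 4 `O=C1O[C@H]([C@@H](O)Cn2cc(CCCCl)nn2)C(OCc2ccccc2)=C1OCc1ccccc1` has not yet been measured. It shares the rest of its structure with compound 2 and differs in one place: 3-chloropropyl in place of 2-methoxyphenyl on an aromatic carbon. Here 3-chloropropyl takes the place of 2-methoxyphenyl on an aromatic carbon of a five-membered aromatic ring with 3 nitrogen.

Within the data shown here, no two measured compounds differ in only one place, so no measured step can size this swap directly. With compound 2 at 50 nM, there seems to be more room for the number to rise than to fall in this assay, so weaker inhibition is the likelier direction. The expected change is a 60-fold higher number from compound 2 to compound 4 (1.78 log units; beyond the scatter), a loose estimate that lies beyond the usual scatter. For compound 4 the estimated value is 3000 nM, with an expected range of 150 nM to 60000 nM.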

Compound 4, half-maximal inhibitory concentration: 27100 nM
Compound 4: middle estimate off by 9.0-fold (0.96 log units), on the low side; measured number inside the range.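

In this assay, this position turns out to be far from indifferent to what it carries, with a 540-fold higher number from compound 2 to compound 4 (2.73 log units; beyond the scatter). The change removes 2-methoxyphenyl, with its six-membered aromatic ring of carbon only, and puts the ringless 3-chloropropyl on the same aromatic carbon, and for this one pair that swap goes with much weaker inhibition. Even so, compound 4 gives an exact number, and it does not reach the limit seen in this assay: the limit of > 100000 nM in this assay, at which 2 of the 4 values shown sit.

The swap changes several things at once, so the compounds shown cannot tell whether losing the ring, losing the methoxy group or gaining the chlorine drives the step. A plain phenyl group or an unchlorinated propyl chain at this position would help pull these apart.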